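Thiourea series: tolerance on human liver cells, compound 3 outlook

The compounds below may be only part of what the source reports. "The series", "measured", "known", "first", "only" and "open" are said of these compounds alone.

Measured so far:
compound 1 `O=C(NC(=S)N1CCc2cc(OCc3ccccc3)ccc21)c1ccccc1` – 45200 nM
compound 2 `N#Cc1cccc(C(=O)NC(=S)N2CCc3c(OCCCCCOc4ccc(Cl)cc4)cccc32)c1` – 9750 nM

Two compounds carry numbers in an ADME assay on Huh-7 cells (Homo sapiens) for cytotoxicity; a higher number here means that more compound is tolerated, a lower number that less compound is tolerated. Compound 1 gives 45200 nM and compound 2 gives 9750 nM, so compound 2 stands at the lower of the two numbers; the gap to compound 1 lies beyond the scatter. The two compounds differ in more than one place, so nothing more than that ordering can be read from them.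

Compound 3 `O=C(NC(=S)N1CCc2c(OCCCCCOc3ccc(Cl)cc3)cccc21)C1CCCC1` is not yet measured. It departs from compound 2 in one place: cyclopentyl in place of 3-cyanophenyl on a carbonyl carbon. The step is written as cyclopentyl in place of 3-cyanophenyl on a carbonyl carbon whose other neighbour is the amide-type nitrogen; the side chain and the shared core are kept.

Going by the values given here, no measured pair in the set isolates this change, so the direction rests on the value of compound 2 alone. The expected step of a 1.5-fold higher number from compound 2 to compound 3 (0.19 log units; within the scatter) is a small rise in tolerated concentration, not clearly beyond the scatter. Compound 3 is estimated at 15000 nM, with a range from 5000 nM to 45000 nM.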

Compound 3, half-maximal cytotoxic concentration: > 50000 nM
Compound 3: no number, only a limit; the forecaster's own chance of this, stated with the estimate: 10%; at least 3.3-fold (0.52 log units) between middle value and limit.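

In this assay, cyclopentyl in place of 3-cyanophenyl on a carbonyl carbon gives an at least 5.1-fold higher number from compound 2 to compound 3 (0.70 log units; beyond the scatter), with the side chain and the shared core kept. Going by these compounds alone, compound 3 gives > 50000 nM, which is a limit and not a number, so the step has a lower bound and its full size stays unknown: the limit of > 50000 nM in this assay, at which 1 of the 3 values shown sits. This is the first comparison that differs in one place, and it shows that the group on this carbonyl carbon alone can move the tolerated concentration beyond the scatter, which compound 1 and compound 2, differing in more than one place, could not show.

The step removes the aromatic ring and the nitrile together, so the compounds shown do not tell which of the two, or the cyclopentyl itself, carries the change; an unsubstituted phenyl or a cyclohexyl on the same carbonyl carbon would begin to separate these. From the compounds shown here alone, whether the same change holds with a shorter chain in place of the side chain, or on the core of compound 1, also remains open.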